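Sulfonamide series: thiazole to dihalophenyl replacement

The compounds below may be only part of what the source reports. "The series", "measured", "known", "first", "only" and "open" are said of these compounds alone.

Measured so far in an ADME assay on S9 fraction from liver (Mus musculus, strain ICR/CD-1) for metabolic stability, read by LC-MS, using NADPH, with a stated time of 5 min, tested at 2 uM; on this read-out lower numbers stand for a shorter-lived compound and higher numbers for a longer-lived compound:
compound 1 `Cc1nc(Cl)sc1S(=O)(=O)N1CCC(N2CCC(C)CC2)CC1` gives 0.167 h
compound 2 `COc1ccc(-c2cccc(S(=O)(=O)N3CCC(N4CCC(C)CC4)CC3)c2)cc1` gives 2.4 h
compound 3 `CC1CCN(C2CCN(S(=O)(=O)c3cccc(-c4ccc5ccccc5c4)c3)CC2)CC1` gives 3.4 h

Compound 1 stands lowest of the three numbers; the nearest is compound 2 and the furthest compound 3, both beyond the scatter from compound 1. Compound 2 and compound 3 are biaryl sulfonamides on the shared core and sit close together: a 1.4-fold higher number from compound 2 to compound 3 (0.15 log units; within the scatter).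

The next compound, compound 4 `CC1CCN(C2CCN(S(=O)(=O)c3ccc(Br)c(Cl)c3)CC2)CC1`, is still to be measured in this assay. It differs from compound 1 in one place: 4-bromo-3-chlorophenyl in place of 2-chloro-4-methyl-1,3-thiazol-5-yl on a sulfonyl sulfur

Within the data shown here, no measured step covers this exchange. Among the measured compounds shown here, the only step in hand, from compound 2 to compound 3, swaps one aryl substituent for another on an aromatic carbon while the sulfonyl-linked phenyl stays, and it lies within the scatter, so it says nothing about replacing the 2-chloro-4-methyl-1,3-thiazol-5-yl itself. What the values show is that the two compounds with a phenyl on the sulfonyl sulfur, compound 2 and compound 3, read far higher than compound 1. Compound 4 also carries a phenyl on that sulfur, though with halogens rather than a second ring, so an upward step is expected, with a wide range: a 6.0-fold higher number from compound 1 to compound 4 (0.78 log units; beyond the scatter). The estimate for compound 4 in this assay is 1 h, between 0.3 h and 3 h.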

Compound 4, half-life: 0.717 h
Compound 4: the middle estimate sits 1.4-fold (0.14 log units) above what was measured, within the range that was stated.
By their numbers in this assay, from the lowest: compound 1; then compound 4; then compounds 2 and 3 (each within the scatter of the next).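

In this assay, the exchange of 2-chloro-4-methyl-1,3-thiazol-5-yl for 4-bromo-3-chlorophenyl on the sulfonyl sulfur, with the rest of the molecule unchanged, gives a 4.3-fold higher number from compound 1 to compound 4 (0.63 log units; beyond the scatter). Among these compounds, this is the only step in hand at this position, and it shows that the ring exchange alone moves the half-life beyond the scatter, though the step is modest. The earlier compounds could not show this, since compound 1 differs from compound 2 and compound 3 in more than one place, whereas compound 4 differs from compound 1 only in this group; no measurement is available to explain the step.

Going by these compounds, it remains open whether the bromine, the chlorine or the pair of halogens on the phenyl ring accounts for the step, and an unsubstituted phenyl or a 4-chlorophenyl on the sulfonyl sulfur would help to separate them. Also open, on these data alone, is how a pyridyl ring, or a phenyl carrying an amine or a carboxylic acid, would read in this place.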